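The source may hold more compounds than are shown below. What is called first, only, known or untested is meant among the compounds shown, and "the series" means these compounds.

For the measured compounds named here, in an ADME assay on HepG2 cells (Homo sapiens) for cytotoxicity, read by MTT assay, with a stated time of 72 h (on this read-out lower numbers stand for higher toxicity in this test and higher numbers for lower toxicity in this test), compound 2 `CC(O)(C#Cc1cc(Cl)cn2c([N+](=O)[O-])c(CS(=O)(=O)c3ccccc3)nc12)c1ccccc1` gives 18800 nM, the only exact number so far. Compound 1 `COc1ccc(C#Cc2cc(Cl)cn3c([N+](=O)[O-])c(CS(=O)(=O)c4ccccc4)nc23)cc1` reads > 3900 nM in this assay, and this value is a limit, not a number. The next compound to be tested is compound 3 `CCC(O)CC#Cc1cc(Cl)cn2c([N+](=O)[O-])c(CS(=O)(=O)c3ccccc3)nc12`, which carries 2-hydroxybutyl in place of 1-hydroxy-1-phenylethyl on a triple-bonded carbon. The change removes the six-membered aromatic ring of carbon only and keeps the hydroxyl-bearing chain on the triple bond. Going by the values given here, the only measured step that bears on it is a step that the limit leaves unreadable from compound 1 to compound 2, so there is no measured size to carry over. The expectation therefore rests on compound 2 at 18800 nM, and no shift beyond the scatter is expected in this assay. The expected step is a 1.2-fold lower number from compound 2 to compound 3 (0.07 log units; within the scatter). For compound 3 the estimated value is 16000 nM, with an expected range from 6000 nM to 40000 nM.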

Compound 3, half-maximal cytotoxic concentration: > 62500 nM
Compound 3: no number, only a limit; the forecaster's own chance of this, stated with the estimate: 35%; at least 3.9-fold (0.59 log units) between middle value and limit.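

For the compounds shown here, putting 2-hydroxybutyl in place of 1-hydroxy-1-phenylethyl on the triple-bonded carbon gives an at least 3.3-fold higher number from compound 2 to compound 3 (0.52 log units; beyond the scatter), the first readable step at this position in this assay, and the higher number stands for lower toxicity in this test. Compound 3 gives > 62500 nM, and this value is a limit, not a number. The steps from compound 1 to the other two compounds cannot be read, because compound 1 also stands at a limit: the limit of > 3900 nM in this assay, at which 1 of the 3 values shown sits.

The change removes the six-membered aromatic ring of carbon only and alters the hydroxyl-bearing chain at once, so the compounds shown do not separate the two. Going by these compounds, it also remains open how an amine or a carboxylic acid in place of the hydroxyl, or a longer chain, would read in this assay.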